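A few compounds are considered here, and "the series" means these few. Any claim that something is new, unique, unknown or untested is made for them only; others in the source may bear on it.

Compounds measured so far:

Compound 1, `CCCCC1CC(=O)N(c2ccccc2C(=O)OCC2CCCN(CCCc3ccccc3)C2)C1=O`, in a functional assay with Neuronal acetylcholine receptor; alpha3/beta4 (Homo sapiens) as the target; a lower number here means a stronger inhibitor, a higher number a weaker inhibitor: 1500 nM
Compound 2, `O=C(OCC1CCCN(CCCc2ccccc2)C1)c1ccccc1N1C(=O)c2ccccc2C1=O`, in this assay: 1300 nM

Among the compounds with values here, of these two numbers, compound 1 has the higher one, but its only neighbour is compound 2 and the step of a 1.2-fold lower number from compound 1 to compound 2 (0.06 log units; within the scatter) lies within the scatter, so the two compounds cannot be ranked against each other. That step exchanges one imide-type group for another at the same aromatic carbon of the shared core, and potency was unmoved by it.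

The next compound, compound 3, `O=C(OCC1CCCN(CCCc2ccccc2)C1)c1ccccc1-c1ccccc1`, carries a different change at that carbon: a group of 6 heavy atoms (6 carbon; one six-membered aromatic ring of carbon only) in place of a group of 11 heavy atoms (8 carbon, 1 nitrogen, 2 oxygen; one five-membered non-aromatic ring with 1 hetero atom), on an aromatic carbon. The entering phenyl brings no hydrogen-bond acceptors, whereas the leaving group carried two, and the entering group is smaller. Within the data shown here, the only step that bears on this change is the one from compound 1 to compound 2, which kept potency unchanged while swapping one acceptor-bearing ring system for another. Nothing measured here tells how the assay reacts to losing those acceptors altogether, so the expectation is for a step of modest size, a little weaker if anything, with wide uncertainty. Compound 3 is therefore expected to give 2200 nM, with a range from 600 nM to 8000 nM. That estimate means an expected step of a 1.5-fold higher number from compound 1 to compound 3 (0.17 log units; within the scatter).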

Compound 3, half-maximal inhibitory concentration: 1700 nM
Compound 3: middle estimate off by 1.3-fold (0.11 log units), on the high side; measured number inside the range.
By their numbers in this assay, from the lowest: compounds 2, 1 and 3 (each within the scatter of the next).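

At this aromatic carbon, ortho to a large group, phenyl in place of the group of compound 1 gives a step that lies within the scatter in this assay (a 1.1-fold higher number from compound 1 to compound 3 (0.05 log units; within the scatter)), and phenyl in place of the group of compound 2 likewise stays within it (a 1.3-fold higher number from compound 2 to compound 3 (0.12 log units; within the scatter)). The earlier pair had only exchanged one acceptor-bearing group for another, whereas this change also removes the hydrogen-bond acceptors counted in the group of compound 1 and leaves a group of fewer heavy atoms, and still no difference can be read among the three compounds, so in this small set the assay does not separate these groups at this position. No outside evidence bears on this result.

The compounds shown leave open whether a much smaller group at this carbon, such as a methyl or a chlorine, or a charged one, such as a carboxylic acid or a primary amine, would move the number beyond the scatter. They also leave open how the assay responds to changes elsewhere on the shared core, such as an amide in place of the ester, which all three compounds keep.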